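A few compounds are considered here, and "the series" means these few. Any claim that something is new, unique, unknown or untested is made for them only; others in the source may bear on it.

Among the measured compounds shown here, in a functional assay on NCI-H460 cells (Homo sapiens) for cytotoxicity, read by MTT assay, with a stated time of 72 h (on this read-out higher numbers stand for weaker inhibition and lower numbers for stronger inhibition), compound 2 (`CC(C)c1[nH]cnc1/C=c1\[nH]c(=O)/c(=C/c2cccc(Oc3ccc(F)cc3)c2)[nH]c1=O`) gives 8.8 nM, the middle of the three numbers known so far. Compound 1 (`CC(C)(C)c1[nH]cnc1/C=c1\[nH]c(=O)/c(=C/c2cccc(C(=O)c3ccc(F)cc3)c2)[nH]c1=O`) gives a lower 3.8 nM, and compound 3 (`O=C(c1ccc(F)cc1)c1cccc(/C=c2\[nH]c(=O)/c(=C/c3c[nH]cn3)[nH]c2=O)c1`) gives a higher 278 nM. Compound 4 (`O=c1[nH]/c(=C\C2CCCCC2)c(=O)[nH]/c1=C\c1cccc(Oc2ccc(F)cc2)c1`) departs from compound 2 in one place: cyclohexyl in place of 5-isopropyl-1H-imidazol-4-yl on a double-bonded chain carbon bound to an aromatic carbon. Cyclohexyl stands in place of 5-isopropyl-1H-imidazol-4-yl on a double-bonded chain carbon bound to an aromatic carbon. For the measured compounds named here, no measured step makes this exchange. The closest guide is a 73-fold higher number from compound 1 to compound 3 (1.86 log units; beyond the scatter), a large step in which only hydrogen replaces tert-butyl on an aromatic carbon. A similarly large rise in the number is therefore expected, an estimated 40-fold higher number from compound 2 to compound 4 (1.60 log units; beyond the scatter). For compound 4 the estimate is 350 nM, with an expected range of 60 nM to 2000 nM.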

Compound 4, half-maximal inhibitory concentration: > 1000 nM
Compound 4: no number, only a limit; the forecaster's own chance of this, stated with the estimate: 5%; at least 2.8-fold (0.45 log units) between middle value and limit.
By their numbers in this assay, from the lowest: compound 1; then compound 2; then compound 3. At a limit, above all of these: compound 4.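

In this assay, compound 4 gives no number, only a limit: the limit of > 1000 nM in this assay, at which 1 of the 4 values shown sits. Cyclohexyl in place of 5-isopropyl-1H-imidazol-4-yl gives an at least 110-fold higher number from compound 2 to compound 4 (2.05 log units; beyond the scatter), showing that this saturated carbon ring does not keep the low number seen with the group it replaces. The earlier step changed only a group on the aromatic ring, whereas here the whole ring leaves, and with it the counted hydrogen-bond donor and acceptor.

The compounds shown cannot separate the loss of aromaticity from the loss of the nitrogens. From the compounds shown here alone, whether a phenyl ring, a pyridine ring or a cyclohexyl ring carrying an amine would restore a low number remains open.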